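The compounds below may be only part of what the source reports. "The series", "measured", "known", "first", "only" and "open" are said of these compounds alone.

Measured compounds:
- compound 1, `Cc1cccc(CSc2ncnc3c2ncn3[C@@H]2O[C@H](CO)[C@@H](O)[C@H]2O)c1`: 12000 nM
- compound 2, `CCCCn1cnc2c(SCc3ccccn3)nc(N)nc21`: 52500 nM

In an assay on isolated protein for binding affinity to Equilibrative nucleoside transporter 1 (Homo sapiens) (a lower number here means a stronger inhibitor, a higher number a weaker inhibitor), compound 2 gives 52500 nM, the higher of the two numbers and so the weaker inhibitor of the pair. Its nearest neighbour is compound 1, which in this assay gives 12000 nM, a gap beyond the scatter; the two share no single-point difference, so their values only mark how far apart they lie. Compound 3, `CCCn1cnc2c(SCc3ccccn3)nc(N)nc21`, follows compound 2 by one change: hydrogen in place of methyl on a saturated chain carbon, three bonds along the chain from an aromatic nitrogen, in other words hydrogen in place of methyl on a saturated chain carbon, three bonds along the chain from an aromatic nitrogen, the chain going from butyl to propyl. For the measured compounds named here, no measured pair shows this kind of trimming, so the expected step is small, most likely none beyond the scatter, with a slight lean toward a weaker inhibitor. The expected step from compound 2 to compound 3 is a 1.2-fold higher number from compound 2 to compound 3 (0.09 log units; within the scatter). Compound 3 is therefore estimated at 65000 nM, with a range from 25000 nM to 170000 nM.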

Compound 3, half-maximal inhibitory concentration: 91200 nM
The estimate for compound 3 lay 1.4-fold (0.15 log units) below the measured number, within the range that was stated.
By their numbers in this assay, from the lowest: compound 1; then compounds 2 and 3 (each within the scatter of the next).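

In this assay shortening the butyl chain to propyl gives a 1.7-fold higher number from compound 2 to compound 3 (0.24 log units; within the scatter) and this is the first pair shown that differs in one place, so it isolates the effect of a single methyl on this chain. Taking away that methyl, on a saturated chain carbon three bonds along the chain from an aromatic nitrogen, gives no change that can be told apart from the ordinary spread of repeat measurements, so butyl and propyl cannot be separated at this position. Nothing available here offers an explanation for the size of this step.

Still open, going by these compounds, is whether a much shorter chain such as ethyl or methyl, or a longer one such as pentyl or hexyl, would shift the number beyond that spread. Also open, on these data alone, is what a hydroxyl or an amine on this chain would do.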